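The source may report more compounds than this note shows. Statements on the series, on what has been measured and on what is new or still open speak of the compounds shown alone.

Measured in a physicochemical assay for solubility, using the shake flask method, measured as kinetic solubility, with a stated time of 20 h, at pH 2; a lower number here means a less soluble compound, a higher number a more soluble compound:

- Compound 1 `COc1cccc(Nc2cc3[nH]c(-c4cccc(C(F)(F)F)c4)nc3cn2)n1`: 85000 nM
- Compound 2 `COc1ccc(Nc2cc3[nH]c(-c4cccc(C(F)(F)F)c4)nc3cn2)nc1`: < 5000 nM, a limit of the assay and not a number
- Compound 3 `FC(F)(F)c1cccc(-c2nc3cnc(Nc4ncccn4)cc3[nH]2)c1`: 155000 nM

Compound 3 stands at the top of these results together with compound 1, the two lying within the scatter of each other: a 1.8-fold higher number from compound 1 to compound 3 (0.26 log units; within the scatter). Compound 2 lies far away, as an at least 31-fold higher number from compound 2 to compound 3 (1.49 log units; beyond the scatter) shows.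

The next compound is compound 4 `FC(F)(F)c1cccc(-c2nc3cnc(Nc4ccncn4)cc3[nH]2)c1`, with pyrimidin-4-yl in place of pyrimidin-2-yl on a nitrogen on an aromatic ring. The two have the same atoms, joined differently.

Within the data shown here, the closest precedent is the exchange of 6-methoxypyridin-2-yl for 5-methoxypyridin-2-yl at that same place, which gave an at least 17-fold lower number from compound 1 to compound 2 (1.23 log units; beyond the scatter). A change of this kind can therefore matter a great deal in this assay. Yet the exchange of 6-methoxypyridin-2-yl for pyrimidin-2-yl gave only a 1.8-fold higher number from compound 1 to compound 3 (0.26 log units; within the scatter). With compound 3 at the top of the results, a moderate step to a lower number is expected, though this rests on very few compounds. The expected change is a 2.6-fold lower number from compound 3 to compound 4 (0.41 log units; beyond the scatter). For compound 4 the estimated value is 60000 nM, with an expected range from 10000 nM to 220000 nM.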

Compound 4, solubility: 200000 nM
Compound 4: middle estimate off by 3.3-fold (0.52 log units), on the low side; the measured number falls inside the stated range.
By their numbers in this assay, from the lowest: compounds 1, 3 and 4 (each within the scatter of the next, the first and the last beyond it). At a limit, below all of these: compound 2.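

In this assay, the exchange of pyrimidin-2-yl for pyrimidin-4-yl on a nitrogen on an aromatic ring, between groups with the same atoms joined differently, gives a 1.3-fold higher number from compound 3 to compound 4 (0.11 log units; within the scatter), so this rearrangement does not carry the large effect seen between the two methoxypyridine groups at this place. Measured from 6-methoxypyridin-2-yl, pyrimidin-4-yl gives a 2.4-fold higher number from compound 1 to compound 4 (0.37 log units; beyond the scatter), a modest step beyond the scatter, whereas pyrimidin-2-yl gave a 1.8-fold higher number from compound 1 to compound 3 (0.26 log units; within the scatter), which stays within it. The remaining step, an at least 40-fold higher number from compound 2 to compound 4 (1.60 log units; beyond the scatter), starts from compound 2, whose entry is a limit of the assay and not a number: the limit of < 5000 nM in this assay, at which 1 of the 4 values shown sits.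

The compounds shown leave open how a pyrimidin-4-yl ring carrying a methoxy group or an amine would read in this assay, and so whether the large gap between 5-methoxypyridin-2-yl and 6-methoxypyridin-2-yl has a counterpart on this ring. As far as these compounds go, it also stays open whether compound 3 and compound 4 would still lie within the scatter of each other if a nitrile or a carboxylic acid stood in place of the trifluoromethyl group.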